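The source may report more compounds than this note shows. Statements on the series, on what has been measured and on what is new or still open speak of the compounds shown alone.

Compound 1 `CC(C)OC(=O)NCCS(=O)(=O)NC(=O)c1ccc(Nc2nc(NC3(c4ccc(Cl)cc4)CC3)nc(OCC(F)(F)F)n2)cc1` is examined in an ADME assay on microsomes from liver (Rattus norvegicus) for metabolic stability, with a stated time of 10 min (on this read-out lower numbers stand for a less stable compound and higher numbers for a more stable compound), where compound 1 gives 73%. Within the data shown here, its only measured neighbour is compound 2 `CN(C)S(=O)(=O)NC(=O)c1ccc(Nc2nc(NC3(c4ccc(Cl)cc4)CC3)nc(OCC(F)(F)F)n2)cc1`, which in this assay gives 76%; the two values lie within the scatter of each other, the step being a number 3 percentage points higher from compound 1 to compound 2 (within the scatter). Compound 3 `NCCS(=O)(=O)NC(=O)c1ccc(Nc2nc(NC3(c4ccc(Cl)cc4)CC3)nc(OCC(F)(F)F)n2)cc1` differs from compound 1 by hydrogen in place of isopropoxycarbonyl on an amine nitrogen. The step from compound 1 to compound 2 also removes the isopropoxycarbonyl, as part of a larger change, and stayed within the scatter, so no step beyond the scatter is expected for compound 3 in this assay, estimated as a number 3 percentage points lower from compound 1 to compound 3 (within the scatter). Compound 3 is expected at 70%, with a range of 50% to 90%.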

Compound 3, percent of the compound remaining: 100%
Compound 3: middle estimate off by 30 percentage points, on the low side; the whole stated range lies below it.
By their numbers in this assay, from the lowest: compounds 1 and 2 (each within the scatter of the next); then compound 3.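

In this assay, the 2-aminoethyl chain sets compound 3 apart: hydrogen in place of isopropoxycarbonyl on the amine nitrogen gives a number 27 percentage points higher from compound 1 to compound 3 (beyond the scatter) and 2-aminoethyl in place of dimethylamino on the sulfonyl sulfur gives a number 24 percentage points higher from compound 2 to compound 3 (beyond the scatter). The read-out therefore does respond to changes at this end of the molecule, which the earlier pair, lying within the scatter, did not show. Nothing available explains this rise. Open, on these data alone, is whether the free amine itself is required: a dimethylamino end on the same ethyl chain, a longer chain carrying the amine, or a carboxylic acid in its place could separate the amine from the chain.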